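Para-substituent swap on the benzyl triazole dithiocarbamates

The source may report more compounds than this note shows. Statements on the series, on what has been measured and on what is new or still open speak of the compounds shown alone.

Three members of the series are known in a functional assay on ECa-109 cells (Homo sapiens) for inhibition, read by MTT assay, with a stated time of 72 h; a lower number here means a stronger inhibitor, a higher number a weaker inhibitor. Compound 1 `COc1ccc(-n2cc(CSC(=S)N3CCN(C(=O)OC(C)(C)C)CC3)nn2)cc1` reaches only the limit of the assay, > 128000 nM. Compound 2 `O=C(OCc1ccccc1)N1CCN(C(=S)SCc2cn(Cc3ccc(Cl)cc3)nn2)CC1` likewise gives a limit, > 128000 nM, and not a number. Compound 3 `CC(C)(C)OC(=O)N1CCN(C(=S)SCc2cn(Cc3cc(=O)oc4cc(O)ccc34)nn2)CC1` also stops at the limit, > 128000 nM. For the measured compounds named here, compound 2 therefore stands where every value so far stands, (the limit of > 128000 nM in this assay, at which 3 of the 3 values shown sit), with no measured step between any two of the three to draw on.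

Compound 4 `COc1ccc(Cn2cc(CSC(=S)N3CCN(C(=O)OCc4ccccc4)CC3)nn2)cc1` differs from compound 2 in one place: methoxy in place of chloro on an aromatic carbon. Going by the values given here, no measured pair shows this exchange or anything related. With all values at the limit, no step beyond the scatter is expected in this assay, in either direction. Compound 4 is expected to sit at 150000 nM, between 60000 nM and 400000 nM, most likely reported again as a limit; the expected step from compound 2 to compound 4 is a step that the limit leaves unreadable from compound 2 to compound 4.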

Compound 4, half-maximal inhibitory concentration: 58300 nM
The estimate for compound 4 lay 2.6-fold (0.41 log units) above the measured number; the whole stated range lies above it.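

In this assay, the change from 4-chlorobenzyl to 4-methoxybenzyl gives an at least 2.1-fold lower number from compound 2 to compound 4 (0.34 log units; beyond the scatter), the first sign that this aromatic carbon, para to a large group, can move the read-out at all. Compound 2 gives > 128000 nM, which is a limit and not a number, so the step has a lower bound but no full size. Compound 4 is the only compound shown that comes off the value shared by the others: the limit of > 128000 nM in this assay, at which 3 of the 4 values shown sit.

From the compounds shown here alone, whether an ethoxy group, a dimethylamino group or a carboxylic acid at the same carbon would go further than methoxy remains open. Also open, going by these compounds, is whether the exchange of chloro for methoxy gives a similar step when the benzyl carbamate of compound 2 is replaced by another carbamate.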